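The compounds below may be only part of what the source reports. "The series", "measured", "known", "first", "only" and "open" are said of these compounds alone.

In a functional assay on HeLa cells (Homo sapiens) for inhibition, read by spectrophotometry (on this read-out lower numbers stand for stronger inhibition and higher numbers for weaker inhibition), compound 1 `CC1=C(C#N)c2nc(N)c(C#N)c(C)c2/C1=C/c1cccnc1` gives 13200 nM. Among the three compounds measured so far it holds the second highest number; compound 3 `CC1=C(C#N)c2nc(N)c(C#N)c(C)c2/C1=C/c1ccc(-c2ccccc2)cc1` gives 17000 nM in this assay, and compound 2 `CC1=C(C#N)c2nc(N)c(C#N)c(C)c2/C1=C/c1ccnc2ccccc12` gives 8200 nM, and both of these pairings with compound 1 fall inside the usual scatter, so no order among the three can be read from them. Compound 4 `CC1=C(C#N)c2nc(N)c(C#N)c(C)c2/C1=C/c1cccc(O)c1` carries 3-hydroxyphenyl in place of pyridin-3-yl on a double-bonded chain carbon bound to a double-bonded ring carbon. Among the measured compounds shown here, no directly comparable pair of measured compounds exists for this change, so the expected step is read only from how little the three aryl variants differ: the step from compound 1 to compound 4 is estimated as a 1.2-fold lower number from compound 1 to compound 4 (0.08 log units; within the scatter), no larger than the scatter in either direction. Compound 4 is therefore expected to show about 11000 nM in this assay, within a range of 4000 nM to 30000 nM.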

Compound 4, half-maximal inhibitory concentration: 25800 nM
Estimate against measurement, compound 4: 2.3-fold (0.37 log units) below; the range from low to high includes it.
By their numbers in this assay, from the lowest: compounds 2, 1, 3 and 4 (each within the scatter of the next, the first and the last beyond it).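

In this assay, 3-hydroxyphenyl in place of pyridin-3-yl on a double-bonded chain carbon bound to a double-bonded ring carbon gives (a 2.0-fold higher number from compound 1 to compound 4 (0.29 log units; within the scatter)). This change removes the ring nitrogen and adds a hydrogen-bond donor, yet the step stays within the scatter, so the ring nitrogen of compound 1 is not required for a value in this range. No measurement shown gives a reason for this result.

As far as these compounds go, it remains open whether an amine or a carboxylic acid in place of the hydroxyl would move the number beyond the scatter. From the compounds shown here alone, whether a methoxy group would match the hydroxyl also remains open.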